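Nitro-oxindole series: cyclic amine exchange at the aromatic carbon

The compounds below may be only part of what the source reports. "The series", "measured", "known", "first", "only" and "open" are said of these compounds alone.

Measured so far:
compound 1 `COc1cc[nH]c1/C=C1\C(=O)Nc2ccc([N+](=O)[O-])c(N[C@H]3CC[C@H](O)CC3)c21` — 8040 nM
compound 2 `COc1cc[nH]c1/C=C1\C(=O)Nc2ccc([N+](=O)[O-])c(N3CCC(O)CC3)c21` — < 10 nM

In a functional assay on RKO cells (Homo sapiens) for antiproliferative activity, read by MTT assay, with a stated time of 5 days (on this read-out higher numbers stand for weaker inhibition and lower numbers for stronger inhibition), compound 1 gives 8040 nM. For compound 2 this assay reports only a limit, < 10 nM. Among the compounds with values here, the single measured step, an at least 800-fold lower number from compound 1 to compound 2 (2.90 log units; beyond the scatter), is the largest feature of the set, and its true size is open at one end, because of the limit of < 10 nM in this assay, at which 1 of the 2 values shown sits. Compound 3 `COc1cc[nH]c1/C=C1\C(=O)Nc2ccc([N+](=O)[O-])c(N3CC[C@@H](N)C3)c21` is the next member; the change is 3-aminopyrrolidin-1-yl in place of 4-hydroxypiperidin-1-yl on an aromatic carbon. The measured step bears on it only indirectly: it shows that the cyclic tertiary amine of compound 2 sits far from the open secondary amine of compound 1, and compound 3 keeps a cyclic tertiary amine at the same aromatic carbon. Within the data shown here, no measured step tests ring size or the exchange of the hydroxyl for the amino group, so the expectation rests on compound 2 alone. The expected step is an at least 1.5-fold higher number from compound 2 to compound 3 (0.17 log units; that floor lies within the scatter), no change beyond the scatter, with wide uncertainty. Compound 3 is therefore estimated at 15 nM in this assay, between 3 nM and 90 nM.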

Compound 3, half-maximal inhibitory concentration: < 10 nM
Compound 3 gave a limit, no number (the forecaster's own chance of this, stated with the estimate: 40%); middle value at least 1.5-fold (0.17 log units) from the limit.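

In this assay compound 3 gives only a limit, < 10 nM. The exchange of (4-hydroxycyclohexyl)amino for 3-aminopyrrolidin-1-yl gives an at least 800-fold lower number from compound 1 to compound 3 (2.90 log units; beyond the scatter), so the low reading at this aromatic carbon is no longer tied to 4-hydroxypiperidin-1-yl alone: it holds for both a six-membered ring carrying a hydroxyl and a five-membered ring carrying an amino group, in each case joined through the ring nitrogen, while compound 1, with its open secondary amine link, stands apart. The step between the two ring-bonded compounds, compound 2 and compound 3, cannot be read, so neither ring size nor the swap of hydroxyl for amino can be ranked here, since both values rest on the same limit: the limit of < 10 nM in this assay, at which 2 of the 3 values shown sit.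

Still open, on these data alone, is how far either ring-bonded compound lies past that limit, and so whether the ring or its hydroxyl or amino group matters at all. An unsubstituted piperidin-1-yl ring, a morpholin-4-yl ring or an open-chain dimethylamino group at this carbon would help separate the role of the ring from that of its substituent.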